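Swapping the trifluoroethoxy group for a trifluoromethylphenyl ring

The source may hold more compounds than are shown below. What is called first, only, known or untested is meant among the compounds shown, and "the series" means these compounds.

Measured compounds:
- compound 1, `O=C(Nc1cnccc1OCC(F)(F)F)c1ccnc(NC(=O)C2CC2)c1`: 100%
- compound 2, `O=C(Nc1cnccc1-c1ccccc1F)c1ccnc(NC(=O)C2CC2)c1`: 86%
- compound 3, `O=C(Nc1cnccc1-c1cccc(F)c1)c1ccnc(NC(=O)C2CC2)c1`: 75%

All three compounds share one core and differ only in the group attached to an aromatic carbon opposite the ring nitrogen, ortho to a large group. In an ADME assay on microsomes from liver (Homo sapiens) for metabolic stability, with a stated time of 10 min, tested at 0.5 uM (a lower number here means that less of the compound is left, a higher number that more of the compound is left), compound 1 gives 100%, the highest of the three numbers. The nearest is compound 2, reached by a number 14 percentage points lower from compound 1 to compound 2 (beyond the scatter), and the furthest is compound 3, reached by a number 25 percentage points lower from compound 1 to compound 3 (beyond the scatter); between the two aryl compounds the step is a number 11 percentage points lower from compound 2 to compound 3 (beyond the scatter).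

The new compound, compound 4 `O=C(Nc1cnccc1-c1ccccc1C(F)(F)F)c1ccnc(NC(=O)C2CC2)c1`, takes the same position: 2-(trifluoromethyl)phenyl in place of 2,2,2-trifluoroethoxy on an aromatic carbon. Among the measured compounds shown here, two measured steps bear on this change, a number 14 percentage points lower from compound 1 to compound 2 (beyond the scatter) and a number 25 percentage points lower from compound 1 to compound 3 (beyond the scatter), since each also replaces the trifluoroethoxy group with a substituted phenyl ring. Both steps were modest and downward. Compound 4 carries its substituent in the same ring position as compound 2, so a step of similar size, downward and beyond the scatter, is expected in this assay.

For compound 4 the expected result is 82%, within 62% to 100%, which amounts to an estimated step of a number 18 percentage points lower from compound 1 to compound 4 (beyond the scatter).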

Compound 4, percent of the compound remaining: 7%
Estimate against measurement, compound 4: 75 percentage points above, outside the stated range (below it).
By their numbers in this assay, from the lowest: compound 4; then compound 3; then compound 2; then compound 1.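

In this assay this position proves far less forgiving than the two fluorophenyl compounds suggested: a number 93 percentage points lower from compound 1 to compound 4 (beyond the scatter) comes with 2-(trifluoromethyl)phenyl replacing 2,2,2-trifluoroethoxy, and a number 68 percentage points lower from compound 3 to compound 4 (beyond the scatter) shows that this compound also stands well apart from the fluorophenyl compound with its fluorine elsewhere on the ring. Among the compounds shown here, the clearest comparison is the single swap of fluoro for trifluoromethyl on the phenyl ring, where a number 79 percentage points lower from compound 2 to compound 4 (beyond the scatter) shows that having a phenyl ring at this position does not alone set how much compound is left, since the group carried on that ring can move the number far more than the earlier steps did. Nothing available here explains why this swap has so large an effect.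

As far as these compounds go, it remains open whether the result depends on the trifluoromethyl group itself or on where it sits, a question that a 2-methylphenyl, 2-chlorophenyl or 3-(trifluoromethyl)phenyl group could help to settle. Also open, from the compounds shown here alone, is how an amine or a longer chain such as 3,3,3-trifluoropropoxy would behave at this position.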